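The source may report more compounds than this note shows. Statements on the series, on what has been measured and on what is new or still open speak of the compounds shown alone.

Working notes on the series, read in a functional assay on A549 cells (Homo sapiens) for inhibition, read by MTT assay, with a stated time of 72 h; on this read-out lower numbers stand for stronger inhibition and higher numbers for weaker inhibition. Compound 1 `CCc1ccc(NC(=O)C2CCN(C/C=C/c3ccccc3)CC2)cc1` gives 19600 nM, compound 2 `O=C(Nc1cccc(Br)c1)C1CCN(C/C=C/c2ccccc2)CC1` gives 16500 nM, and compound 3 `O=C(Nc1ccc(F)c(Br)c1)C1CCN(C/C=C/c2ccccc2)CC1` gives 11700 nM. Compound 1 is not separated from either of the others: the nearest step is a 1.2-fold lower number from compound 1 to compound 2 (0.07 log units; within the scatter), and the furthest is a 1.7-fold lower number from compound 1 to compound 3 (0.22 log units; within the scatter). The remaining step, a 1.4-fold lower number from compound 2 to compound 3 (0.15 log units; within the scatter), adds fluoro on an aromatic carbon and is no larger.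

Next is compound 4 `CN1CCN(c2ccc(NC(=O)C3CCN(C/C=C/c4ccccc4)CC3)cc2)CC1`, which keeps the core of compound 1 and carries one change: 4-methylpiperazin-1-yl in place of ethyl on an aromatic carbon. 4-Methylpiperazin-1-yl stands in place of ethyl on an aromatic carbon, para to a large group.

The nearest evidence is the pair of replacements of the 4-ethylphenyl on the amide-type nitrogen, a 1.2-fold lower number from compound 1 to compound 2 (0.07 log units; within the scatter) and a 1.7-fold lower number from compound 1 to compound 3 (0.22 log units; within the scatter). Neither moved the number beyond the scatter. For the measured compounds named here, they are only partial guides, since no measured compound carries a 4-methylpiperazin-1-yl group, and the direction of any shift cannot be read from them. No step beyond the scatter is therefore expected, and the estimated change is a 1.4-fold lower number from compound 1 to compound 4 (0.15 log units; within the scatter). For compound 4 the estimated value is 14000 nM, with an expected range of 5000 nM to 32000 nM.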

Compound 4, half-maximal inhibitory concentration: 19900 nM
Compound 4: middle estimate off by 1.4-fold (0.15 log units), on the low side, within the range that was stated.
By their numbers in this assay, from the lowest: compounds 3, 2, 1 and 4 (each within the scatter of the next).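

In this assay the exchange at this position, on an aromatic carbon para to a large group, gives a small step: a 1.0-fold higher number from compound 1 to compound 4 (0.01 log units; within the scatter). The earlier steps shown here swapped the whole 4-ethylphenyl for bromo-bearing phenyl groups or added fluoro, whereas this one keeps the ring and shows that a much larger substituent can stand here without a step beyond the scatter: 4-methylpiperazin-1-yl brings 7 heavy atoms against 2 for ethyl, a six-membered non-aromatic ring with 2 hetero atoms, and 2 hydrogen-bond acceptors against 0. No measured property of either group is available to account for this result.

Going by these compounds, whether any substituent at this position can move the number beyond the scatter stays open, for instance a carboxylic acid, a primary amine or a longer alkyl chain. With a single exchange at this place, the compounds shown also cannot tell whether the ring, the nitrogens or the terminal methyl of 4-methylpiperazin-1-yl matters on its own.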